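The compounds below may be only part of what the source reports. "The series", "measured", "known", "first", "only" and "open" are said of these compounds alone.

Three compounds share one core and differ only in the aromatic group attached to a sulfonyl sulfur. Compound 1 `Cc1ccc2[nH]c(C(=O)N[C@H]3CN(S(=O)(=O)c4ccccc4)C[C@@H]3C(=O)NCCN(C)C)cc2c1` carries a phenyl there; in a functional assay on HEK293 cells for agonist activity at growth hormone secretagogue receptor type 1 (Homo sapiens), read by HTRF and inositol phosphate accumulation, with a stated time of 90 min, in the presence of a further agent that is not named here (on this read-out higher numbers stand for larger maximal responses and lower numbers for smaller maximal responses), compound 1 gives 93%. Compound 2 `Cc1ccc2[nH]c(C(=O)N[C@H]3CN(S(=O)(=O)c4cccnc4)C[C@@H]3C(=O)NCCN(C)C)cc2c1` carries a pyridin-3-yl instead; in this assay compound 2 gives 90%. Compound 3 `Cc1ccc2[nH]c(C(=O)N[C@H]3CN(S(=O)(=O)c4ccnnc4)C[C@@H]3C(=O)NCCN(C)C)cc2c1` carries a pyridazin-4-yl; in this assay compound 3 gives 89%. Compound 3 holds the lowest of the three numbers, but the gaps are small: a number 4 percentage points lower from compound 1 to compound 3 (within the scatter) and a number 1 percentage points lower from compound 2 to compound 3 (within the scatter), both within the scatter, as is a number 3 percentage points lower from compound 1 to compound 2 (within the scatter). In effect the three maximal responses cannot be told apart.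

Compound 4 `Cc1ccc2[nH]c(C(=O)N[C@H]3CN(S(=O)(=O)c4cn(C)nc4C)C[C@@H]3C(=O)NCCN(C)C)cc2c1` is not yet measured. It differs from compound 3 in one place: 1,3-dimethyl-1H-pyrazol-4-yl in place of pyridazin-4-yl on a sulfonyl sulfur. All three measured steps bear on this change, since each swaps one aromatic ring for another on the same sulfonyl sulfur, and none of them moved the maximal response beyond the scatter. Among the compounds with values here, a five-membered ring enters here for the first time, so the measured steps do not cover this exact swap; still, the closest evidence points to no step beyond the scatter. The expected step is a number 1 percentage points lower from compound 3 to compound 4 (within the scatter). Compound 4 is therefore estimated at 88%, with a range from 78% to 98%.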

Compound 4, largest response reached (Emax), in percent of the reference or control that the assay uses: 95%
Compound 4: middle estimate off by 7 percentage points, on the low side, within the range that was stated.
By their numbers in this assay, from the lowest: compounds 3, 2, 1 and 4 (each within the scatter of the next).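

The result shows that this position on the sulfonyl sulfur accepts more than six-membered aromatic rings: with the five-membered 1,3-dimethyl-1H-pyrazol-4-yl in place, this assay gives a number 6 percentage points higher from compound 3 to compound 4 (within the scatter), a number 5 percentage points higher from compound 2 to compound 4 (within the scatter) and a number 2 percentage points higher from compound 1 to compound 4 (within the scatter). A change in ring size, together with the two methyl groups that the new ring carries, therefore leaves the maximal response indistinguishable from that of all three earlier compounds, so the four groups on this sulfur cannot be ranked by this read-out. No measurement shown here offers an explanation for how these four compounds compare.

On these data alone, whether the response would hold with a group of a different kind on the sulfur, such as a plain methyl, a saturated cyclohexyl ring or a phenyl bearing a carboxylic acid or an amine, remains open. Also open, as far as these compounds go, is whether these four aromatic groups differ in some other respect, such as the concentration needed to reach the response, since the largest response reached says nothing about that.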